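The source may hold more compounds than are shown below. What is called first, only, known or untested is meant among the compounds shown, and "the series" means these compounds.

Going by the values given here, compound 2 `Cc1ccc(S(=O)(=O)/N=C(/CCNC2=CC(=O)c3ccccc3C2=O)Nc2ccc(Cl)cc2Cl)cc1` gives 20500 nM in a functional assay on HeLa cells (Homo sapiens) for cytotoxicity, read by MTT assay, with a stated time of 48 h (on this read-out higher numbers stand for weaker inhibition and lower numbers for stronger inhibition), the highest of the two numbers so far; compound 1 `Cc1ccc(S(=O)(=O)/N=C(/CCNC2=CC(=O)c3ccccc3C2=O)Nc2ccccc2[N+](=O)[O-])cc1` gives 3310 nM, and the step of a 6.2-fold higher number from compound 1 to compound 2 (0.79 log units; beyond the scatter) separates them. Compound 3 `Cc1ccc(S(=O)(=O)/N=C(/CCNC2=CC(=O)c3ccccc3C2=O)NC2CCCCC2)cc1` differs from compound 2 by cyclohexyl in place of 2,4-dichlorophenyl on an amine nitrogen. Among the compounds with values here, the only measured step exchanges one substituted phenyl for another and does not cover the loss of an aromatic ring, so it bears on this change only loosely. A step of a 1.7-fold lower number from compound 2 to compound 3 (0.23 log units; within the scatter) is expected, read with wide uncertainty. The estimate for compound 3 is 12000 nM, between 3000 nM and 45000 nM.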

Compound 3, half-maximal inhibitory concentration: 9770 nM
For compound 3 the middle estimate is 1.2-fold (0.09 log units) above the measured one, and the stated range covers the measured number.
By their numbers in this assay, from the lowest: compound 1; then compound 3; then compound 2.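

Cyclohexyl brings the first non-aromatic ring to this amine nitrogen, and in this assay it lands between the two substituted phenyl compounds, with a 2.1-fold lower number from compound 2 to compound 3 (0.32 log units; beyond the scatter) and a 3.0-fold higher number from compound 1 to compound 3 (0.47 log units; beyond the scatter). An aromatic ring on this nitrogen is therefore not required for activity in this range, though 2-nitrophenyl still gives the lowest number of the three. No measurement on hand accounts for this order.

On these data alone, whether unsubstituted phenyl, cyclopentyl or an open-chain butyl group on this nitrogen would fit the same order stays open.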